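Methoxy on the Benzyl Ring of Compound 3

This account rests on a few compounds, and the source may have more. Where it says the series, first, only, none or still open, it means among the compounds named here.

Compound 1 `N#Cc1c(-c2cccc(Br)c2)nc(SCc2ccccc2)[nH]c1=O`: > 36000 nM
Compound 2 `O=c1[nH]c(SCc2cc([N+](=O)[O-])cc([N+](=O)[O-])c2)nc2ccccc12`: > 64000 nM
Compound 3 `O=c1[nH]c(SCc2ccccc2)nc2ccccc12`: > 64000 nM

All three entries come from an ADME assay on MRC5 cells (Homo sapiens) for cytotoxicity, read by neutral red uptake (a lower number here means that less compound is tolerated, a higher number that more compound is tolerated), and none of them is an exact number. Compound 1 gives > 36000 nM, which is a limit of the assay. Compound 2 gives > 64000 nM, also a limit. Compound 3 likewise gives only a limit, and it stands at the limit of > 64000 nM in this assay, at which 2 of the 3 values shown sit.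

Compound 4 `COc1ccc(CSc2nc3ccccc3c(=O)[nH]2)cc1` has not yet been measured. It carries methoxy in place of hydrogen on an aromatic carbon, para to a large group: methoxy in place of hydrogen on an aromatic carbon. Among the measured compounds shown here, no two measured compounds differ in one place, so the size of such a change has not been observed in this assay. No shift beyond the usual scatter is expected, and the estimated step of a number no higher from compound 3 to compound 4 (the limit leaves the size open) reflects this. That expectation rests on compound 3, whose > 64000 nM is a limit. Compound 4 is expected at 64000 nM, with an estimated range from 32000 nM to 128000 nM.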

Compound 4, half-maximal cytotoxic concentration: > 64000 nM
Compound 4: a limit, no number; the forecaster's own chance of this, stated with the estimate: 80%; the middle value lies on the limit itself.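

In this assay compound 4 gives > 64000 nM, which is a limit of the assay. Compound 3 also has only a limit, so no step can be read between compound 3 and compound 4. The compounds shown leave open whether methoxy in place of hydrogen on an aromatic carbon changes the half-maximal cytotoxic concentration at all.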